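Methoxy to Hydroxy at the Edge of the Assay Limit

The source may report more compounds than this note shows. Statements on the series, on what has been measured and on what is new or still open speak of the compounds shown alone.

In a functional assay on H184B5F5/M10 cells (Homo sapiens) for antiproliferative activity, read by MTT assay, with a stated time of 24 h (on this read-out lower numbers stand for stronger inhibition and higher numbers for weaker inhibition), compound 3 `COc1ccc(C(=O)NNC(=O)/C=C/c2cc(OC)c(O)c(OC)c2)cc1` is the only one of the three measured compounds with an actual number, 9450 nM. Compound 1 `COc1ccc(C(=O)NNC(=O)/C=C/c2ccc(O)c(OC)c2)cc1` gives only a limit, > 10000 nM. Compound 2 `COc1cc(/C=C/C(=O)NNC(=O)c2ccccc2)cc(OC)c1O` also gives only a limit, > 10000 nM.

Compound 4 `COc1cc(/C=C/C(=O)NNC(=O)c2ccc(O)cc2)cc(OC)c1O` differs from compound 3 by hydrogen in place of methyl on an oxygen on an aromatic ring, which turns 4-methoxyphenyl to 4-hydroxyphenyl: hydrogen in place of methyl on an oxygen on an aromatic ring. Among the measured compounds shown here, no measured step makes this exact change. The nearest are two steps that put methoxy in place of hydrogen on an aromatic carbon, an at least 1.0-fold lower number from compound 1 to compound 3 (0.02 log units; that floor lies within the scatter) and an at least 1.0-fold lower number from compound 2 to compound 3 (0.02 log units; that floor lies within the scatter), and the second of these creates the 4-methoxyphenyl group. Going by these compounds, both are floors within the scatter, and both rest on (the limit of > 10000 nM in this assay, at which 2 of the 3 values shown sit), so their true size stays open.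

For the measured compounds named here, with only that guide, no step beyond the scatter is expected, and the estimated change is a 1.1-fold lower number from compound 3 to compound 4 (0.02 log units; within the scatter). Compound 4 is expected at 9000 nM, with an estimated range of 4000 nM to 20000 nM.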

Compound 4, half-maximal inhibitory concentration: > 10000 nM
Compound 4 ended at the assay's limit; the forecaster's own chance of this, stated with the estimate: 50%; at least 1.1-fold (0.04 log units) between middle value and limit.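

The change from methoxy to hydroxy now has a direct reading, an at least 1.0-fold higher number from compound 3 to compound 4 (0.02 log units; that floor lies within the scatter) in this assay, and this floor does not show that the change matters. Among hydrogen, hydroxy and methoxy on this ring, only methoxy gives a compound with a number, but that number lies so close to the limit that this sets the methoxy group apart only weakly. The step between compound 2 and compound 4, where hydroxy replaces hydrogen on this ring, cannot be read, so the hydroxy group's effect relative to hydrogen stays hidden: the limit of > 10000 nM in this assay, at which 3 of the 4 values shown sit.

Going by these compounds, how far compound 2 and compound 4 actually lie past the limit remains open. Also open, on these data alone, is whether an amine or a carboxylic acid at this place would give a clearly lower number.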